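From One Thiophene Group to Another

The source may hold more compounds than are shown below. What is called first, only, known or untested is meant among the compounds shown, and "the series" means these compounds.

In a functional assay on A549 cells (Homo sapiens) for cytotoxicity (on this read-out lower numbers stand for stronger inhibition and higher numbers for weaker inhibition), compound 3 `C=C/C=C\[C@H](C)[C@H](OC(N)=O)[C@@H](C)[C@H](O)[C@@H](C)C/C(C)=C\[C@H](C)[C@@H](O)[C@@H](C)/C=C\CCc1sccc1C` gives 790 nM and so stands level with compound 1 `C=C/C=C\[C@H](C)[C@H](OC(N)=O)[C@@H](C)[C@H](O)[C@@H](C)C/C(C)=C\[C@H](C)[C@@H](O)[C@@H](C)/C=C\CCc1cccc(O)c1C` at 910 nM and compound 2 `C=C/C=C\[C@H](C)[C@H](OC(N)=O)[C@@H](C)[C@H](O)[C@@H](C)C/C(C)=C\[C@H](C)[C@@H](O)[C@@H](C)/C=C\CCc1cc(F)cc(F)c1` at 1000 nM on the shared core. None of the three can be ranked on these numbers. Moving to compound 4 `C=C/C=C\[C@H](C)[C@H](OC(N)=O)[C@@H](C)[C@H](O)[C@@H](C)C/C(C)=C\[C@H](C)[C@@H](O)[C@@H](C)/C=C\CCc1ccsc1` brings the change thiophen-3-yl in place of 3-methylthiophen-2-yl on a saturated chain carbon, two bonds along the chain from a double-bonded chain carbon in which thiophen-3-yl takes the place of 3-methylthiophen-2-yl on a saturated chain carbon, two bonds along the chain from a double-bonded chain carbon. Three measured swaps of this same group bear on it: a 1.1-fold higher number from compound 1 to compound 2 (0.04 log units; within the scatter) and a 1.2-fold lower number from compound 1 to compound 3 (0.06 log units; within the scatter) and also a 1.3-fold lower number from compound 2 to compound 3 (0.10 log units; within the scatter) on the same read-out. All three stayed small, so no step beyond the scatter is expected in this assay for this swap. Going by the values given here, no measured compound carries thiophen-3-yl, however, so this expectation is an inference from other groups. The expected step is a 1.1-fold higher number from compound 3 to compound 4 (0.06 log units; within the scatter) and nothing larger. For compound 4 the estimated value is 900 nM with an expected range of 450 nM to 1800 nM across repeated measurements.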

Compound 4, half-maximal inhibitory concentration: 4000 nM
Compound 4: the middle estimate sits 4.4-fold (0.65 log units) below what was measured, and the stated range ends below it.
By their numbers in this assay, from the lowest: compounds 3, 1 and 2 (each within the scatter of the next); then compound 4.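

The swap to thiophen-3-yl gives a 5.1-fold higher number from compound 3 to compound 4 (0.70 log units; beyond the scatter) in this assay, and the other two comparisons agree, with a 4.0-fold higher number from compound 2 to compound 4 (0.60 log units; beyond the scatter) and a 4.4-fold higher number from compound 1 to compound 4 (0.64 log units; beyond the scatter). So this place on the chain is not indifferent to the group it carries, even though 3-methylthiophen-2-yl, 3,5-difluorophenyl and 3-hydroxy-2-methylphenyl stand level there and thiophen-3-yl alone stands apart. Nothing available here explains the change.

Two things differ between the thiophene groups of compound 3 and compound 4, the methyl and the ring carbon joined to the chain, and a plain thiophen-2-yl group would help to separate them. On these data alone, it also remains open whether an unsubstituted phenyl group would stand with compound 4 or with the other three compounds.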